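Steady-state distribution in rat: outlook for compound 3

The source may report more compounds than this note shows. Statements on the series, on what has been measured and on what is new or still open speak of the compounds shown alone.

Two compounds have so far been run in an ADME assay on the whole organism (Rattus norvegicus, strain Sprague-Dawley) for pharmacokinetics, read by LC-MS, with a stated time of 24 h, at a dose of 1 mg/kg by the intravenous route; a higher number here means that more of the compound sits outside the plasma, a lower number that more of the compound stays in the plasma. Compound 1 `Cn1nccc1-c1cc(C(F)(F)F)ccc1[C@H]1CCc2cc(S(=O)(=O)Nc3ncccn3)ccc21` gives 1 L/kg. Compound 2 `O=S(=O)(Nc1ncccn1)c1ccc2c(c1)OCC[C@@H]2c1ccc(C(F)(F)F)cc1-c1ccc(F)nc1` gives 1.2 L/kg, the higher of the two numbers, but its gap to compound 1 lies within the scatter, so the two read alike on this measure. Compound 3 `Cn1nccc1-c1cc(C(F)(F)F)ccc1[C@H]1CCOc2cc(S(=O)(=O)Nc3ncccn3)ccc21` has not yet been measured. Against compound 2 it differs at a single place: 1-methyl-1H-pyrazol-5-yl in place of 6-fluoropyridin-3-yl on an aromatic carbon. The same 1-methyl-1H-pyrazol-5-yl group already stands in compound 1, whose value in this assay sits within the scatter of that of compound 2, so the change gives no reason to expect a step beyond the scatter in either direction. Compound 3 is therefore expected to come in at 1.1 L/kg, with a range from 0.6 L/kg to 2 L/kg. The step that this estimate implies, a 1.1-fold lower number from compound 2 to compound 3 (0.04 log units; within the scatter), is expected to be flat, within the scatter.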

Compound 3, volume of distribution at steady state: 0.9 L/kg
The estimate for compound 3 lay 1.2-fold (0.09 log units) above the measured number, and the stated range covers the measured number.
By their numbers in this assay, from the lowest: compounds 3, 1 and 2 (each within the scatter of the next).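

In this assay, 1-methyl-1H-pyrazol-5-yl in place of 6-fluoropyridin-3-yl, on an aromatic carbon ortho to a large group and meta to a trifluoromethyl group, now has a direct reading: a 1.3-fold lower number from compound 2 to compound 3 (0.12 log units; within the scatter). On this shared core, a five-membered aromatic ring with 2 hetero atoms and a six-membered aromatic ring with 1 hetero atom therefore read alike at this position. Nothing at hand bears on why these two groups read alike.

On these data alone, whether a group of another kind at this position, such as a carboxylic acid or a primary amine, would also stay within the scatter remains open. This single pair also leaves open whether the same exchange would read alike on the core of compound 1.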